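Benzoyl in place of phenylsulfonyl: cytotoxicity outlook

The compounds below may be only part of what the source reports. "The series", "measured", "known", "first", "only" and "open" are said of these compounds alone.

Compound 3 `O=c1cc(N2CCN(CC3CCC(OS(=O)(=O)c4ccccc4)CC3)CC2)sc2c([N+](=O)[O-])cc(C(F)(F)F)cc12` gives in an ADME assay on Vero cells (Chlorocebus sabaeus) for cytotoxicity, read by MTT assay, with a stated time of 48 h (a lower number here means a stronger inhibitor, a higher number a weaker inhibitor), only a limit, > 64 ug/mL. Compound 1 `COc1ccccc1C(=O)OC1CCC(CN2CCN(c3cc(=O)c4cc(C(F)(F)F)cc([N+](=O)[O-])c4s3)CC2)CC1` gives in this assay likewise a limit, > 64 ug/mL. Compound 2 `O=C(OC1CCC(CN2CCN(c3cc(=O)c4cc(C(F)(F)F)cc([N+](=O)[O-])c4s3)CC2)CC1)c1cccs1` gives in this assay a limit as well, > 64 ug/mL. Compound 3 therefore stands where every measured member of the series stands, at the limit of > 64 ug/mL in this assay, at which 3 of the 3 values shown sit. Compound 4 `O=C(OC1CCC(CN2CCN(c3cc(=O)c4cc(C(F)(F)F)cc([N+](=O)[O-])c4s3)CC2)CC1)c1ccccc1` differs from compound 3 by benzoyl in place of phenylsulfonyl on an oxygen on a saturated carbon. The measured steps that bear on this change are a step that the two limits leave unreadable from compound 1 to compound 3 and a step that the two limits leave unreadable from compound 2 to compound 3, together with a step that the two limits leave unreadable from compound 1 to compound 2; none of them yields a readable size. The step expected in this assay is accordingly none beyond the scatter, namely a step that the limit leaves unreadable from compound 3 to compound 4. Compound 4 is expected to give 80 ug/mL, between 40 ug/mL and 200 ug/mL, most probably again reported only as a limit.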

Compound 4, half-maximal inhibitory concentration: > 64 ug/mL
Compound 4 was reported as a limit; the forecaster's own chance of this, stated with the estimate: 85%; the middle value does not contradict the limit.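

For the compounds shown here, compound 4 sits at a limit in this assay, as do compound 1, compound 2 and compound 3, so no step among them can be read: the limit of > 64 ug/mL in this assay, at which 4 of the 4 values shown sit. Still open, from the compounds shown here alone, is whether benzoyl and phenylsulfonyl differ at all in this assay.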